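Shortening the chain of a trifluoromethyl ketone

This account rests on a few compounds, and the source may have more. Where it says the series, first, only, none or still open, it means among the compounds named here.

Compound 1 `CCCCCCCCCCCCCC(=O)C(F)(F)F` and compound 2 `CCCCCCCCCC(=O)C(F)(F)F` are both trifluoromethyl ketones that differ only in the length of the saturated chain. In an assay on liver for inhibition of Fatty-acid amide hydrolase 1 (Rattus norvegicus) (a higher number here means a weaker inhibitor, a lower number a stronger inhibitor), compound 1 gives 490 nM, and compound 2 gives 130 nM. Of these two numbers, compound 2 holds the lower one, and the step of a 3.8-fold lower number from compound 1 to compound 2 (0.58 log units; beyond the scatter) lies beyond the scatter. Compound 3 `CCCCCCC(=O)C(F)(F)F` takes the same direction one stage further: it differs from compound 2 by hydrogen in place of propyl on a saturated chain carbon, six bonds along the chain from a carbonyl carbon. Among the compounds with values here, only the step from compound 1 to compound 2 bears on this change, and it shortened the chain in the same sense, with a modest gain. A second shortening of the same kind, at a position closer to the carbonyl, is therefore expected to give either a smaller gain or none beyond the scatter; nothing in the two measured compounds shows where such a trend might turn. On that basis compound 3 is estimated to show the step of a 1.6-fold lower number from compound 2 to compound 3 (0.21 log units; within the scatter) in this assay. Compound 3 is thus expected to give about 80 nM, with a plausible range from 25 nM to 300 nM.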

Compound 3, inhibition constant: 10700 nM
For compound 3 the middle estimate is 130-fold (2.13 log units) below the measured one; measured number above the stated range.
By their numbers in this assay, from the lowest: compound 2; then compound 1; then compound 3.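

In this assay, hydrogen in place of propyl, six bonds along the chain from a carbonyl carbon, gives an 82-fold higher number from compound 2 to compound 3 (1.92 log units; beyond the scatter) and so reverses the direction seen earlier. The earlier change, a 3.8-fold lower number from compound 1 to compound 2 (0.58 log units; beyond the scatter), was a modest gain, whereas this one is a large loss, so shortening the saturated chain does not act in one direction across these three compounds. Compound 2 holds the lowest number of the three, with the longer chain of compound 1 and the shorter chain of compound 3 both giving higher numbers, and compound 3 gives the highest.

Still open, on these data alone, is whether the number climbs gradually or abruptly over chains lying between those of compound 2 and compound 3, and whether the lowest number for this series lies at compound 2 or at a neighbouring chain length. Also open, as far as these compounds go, is whether a phenyl ring or a carboxylic acid in place of the propyl that compound 3 lacks would bring the number back down. Nothing available here accounts for the size of this loss at this position.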